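The compounds below may be only part of what the source reports. "The series", "measured", "known", "first", "only" and "open" are said of these compounds alone.

Compound 1, `COC(=O)c1ccc(NCc2cncn2Cc2ccc(C(C)(C)C)cc2)cc1-c1ccccc1`: in a toxicity assay on NIH3T3 cells (Mus musculus) for cytotoxicity, read by resazurin assay (a lower number here means that less compound is needed, a higher number that more compound is needed for the effect), compound 1 gives "not determined" (no result reported).
Compound 2, `COC(=O)c1ccc(NCc2cncn2Cc2cccc(F)c2)cc1-c1ccccc1`: in this assay compound 2 gives > 1000 nM, which is a limit of the assay and not a number.
Compound 3, `COC(=O)c1ccc(NCc2cncn2Cc2cccc(OC)c2)cc1-c1ccccc1`: in this assay compound 3 gives "not determined" (no result reported).

Compound 3 therefore stands without a single number in this assay. Of the three entries shown, one further value is only a limit, namely (the limit of > 1000 nM in this assay, at which 1 of the 3 values shown sits), and one further entry has no number at all. Within the data shown here, no pair of measured compounds differs in just one place, so no measured step can be drawn between any two of them, and there is nothing to compare compound 3 against directly.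

Compound 4, `COC(=O)c1ccc(NCc2cncn2Cc2ccccc2Br)cc1-c1ccccc1`, is the compound still to be measured. It differs from compound 3 in one place: 2-bromophenyl in place of 3-methoxyphenyl on a saturated chain carbon bound to an aromatic nitrogen. 

Among the measured compounds shown here, with no measured step to lean on, and with the only result in this assay being a limit, no step beyond the usual scatter is expected here, in either direction; the most likely outcome is again a limit rather than a number. For compound 4 in this assay the estimate is 3000 nM, expected to fall somewhere between 1000 nM and 30000 nM.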

Compound 4, half-maximal effective concentration: 10000 nM
Compound 4: the middle estimate sits 3.3-fold (0.52 log units) below what was measured; low and high end bracket the measured number.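

The step from compound 2 to compound 4 in this assay cannot be read, because compound 2 has only a limit and not a number: the limit of > 1000 nM in this assay, at which 1 of the 4 values shown sits.

The compounds shown leave open how 2-bromophenyl compares with 3-fluorophenyl or 3-methoxyphenyl in this assay, since only compound 4 has a single number.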